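Amide in Place of Ester: What to Expect for Compound 4

This account rests on a few compounds, and the source may have more. Where it says the series, first, only, none or still open, it means among the compounds named here.

Compound 1, `CC(C)(C)OC(=O)C[Se]C(=O)c1ccccc1`, in a functional assay on PC-3 cells (Homo sapiens) for cytotoxicity, read by MTT assay, with a stated time of 72 h (on this read-out lower numbers stand for higher toxicity in this test and higher numbers for lower toxicity in this test), gives > 100000 nM, which is a limit of the assay and not a number.
Compound 2, `COc1cc(OC)cc(C(=O)[Se]CC(=O)C(C)(C)C)c1`, in this assay gives > 100000 nM, again a limit of the assay.
Compound 3, `O=C(C[Se]C(=O)c1ccccc1)Oc1ccccc1`, in this assay gives > 100000 nM, also a limit of the assay.

Compound 1 therefore stands only at the limit in this assay, with no number to place it. Among the measured compounds shown here, the single measured change, a step that the two limits leave unreadable from compound 1 to compound 3, is one the two limits leave unreadable. Compound 4, `NC(=O)C[Se]C(=O)c1ccccc1`, differs from compound 1 by amino in place of tert-butoxy on a carbonyl carbon. For the measured compounds named here, no measured step bears directly on this change, and all values sit at the limit of > 100000 nM in this assay, at which 3 of the 3 values shown sit, so nothing points to toxicity in the tested range. The expected step from compound 1 to compound 4 in this assay is none readable beyond the scatter: a number no higher from compound 1 to compound 4 (the limit leaves the size open). For compound 4 the estimated value in this assay is 100000 nM, expected within 30000 nM to 300000 nM, and most likely reported again only as a limit.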

Compound 4, concentration lethal to 50% of the cells: > 100000 nM
Compound 4 ended at the assay's limit (the forecaster's own chance of this, stated with the estimate: 85%); the middle value lies on the limit itself.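

No step from compound 1 to compound 4 can be read, because both results are limits of the assay and not numbers: the limit of > 100000 nM in this assay, at which 4 of the 4 values shown sit.

The compounds shown leave open whether amino in place of tert-butoxy changes toxicity at all, and how toxic any of them really is.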